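The compounds below may be only part of what the source reports. "The series", "measured", "known", "first", "only" and "open" are said of these compounds alone.

Measured in a functional assay on HCT-116 cells (Homo sapiens) for inhibition, read by CCK-8 assay, with a stated time of 48 h; on this read-out higher numbers stand for weaker inhibition and lower numbers for stronger inhibition:
Compound 1 `CCN1CCN(C(=S)SCC(=O)N(Cc2ccc(OC)cc2)c2cc(OC)c(OC)c(OC)c2)CC1`: 7700 nM
Compound 2 `COc1ccc(CN(C(=O)CSC(=S)N2CCc3cc(Br)ccc32)c2cc(OC)c(OC)c(OC)c2)cc1`: 8060 nM

Compound 1 and compound 2 stand level, with a 1.0-fold higher number from compound 1 to compound 2 (0.02 log units; within the scatter). Compound 3 `CCN1CCN(CC(=O)N(Cc2ccc(OC)cc2)c2cc(OC)c(OC)c(OC)c2)CC1` is still unmeasured and differs from compound 1 by a group of 8 heavy atoms (6 carbon, 2 nitrogen; one six-membered non-aromatic ring with 2 hetero atoms) in place of a group of 11 heavy atoms (7 carbon, 2 nitrogen, 2 sulfur; one six-membered non-aromatic ring with 2 hetero atoms), on a saturated chain carbon bound to a carbonyl carbon. Among the measured compounds shown here, the one measured step swapped the group on a thiocarbonyl carbon but kept that carbon, whereas compound 3 has no thiocarbonyl, so the step offers only loose guidance. With that guidance, no change beyond the scatter is expected in this assay, and the estimated step is a 1.2-fold higher number from compound 1 to compound 3 (0.07 log units; within the scatter). For compound 3 the expected value is 9000 nM, with an estimated range of 3000 nM to 30000 nM.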

Compound 3, half-maximal inhibitory concentration: > 20000 nM
Compound 3 ended at the assay's limit (the forecaster's own chance of this, stated with the estimate: 15%); at least 2.2-fold (0.34 log units) between middle value and limit.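

In this assay, taking away the thiocarbonyl and its sulfur link, so that 4-ethylpiperazin-1-yl sits on a saturated chain carbon bound to a carbonyl carbon, gives an at least 2.5-fold higher number from compound 1 to compound 3 (0.41 log units; beyond the scatter). The earlier swap kept the thiocarbonyl carbon and stayed within the scatter, so this is the first change shown here that weakens inhibition. The value of compound 3 is a limit, not a number, so the true size of this step stays unknown: the limit of > 20000 nM in this assay, at which 1 of the 3 values shown sits.

Which part of the lost group matters remains open. A thioether or a carbamate in its place could help separate the role of the sulfur link from that of the thiocarbonyl.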